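The source may hold more compounds than are shown below. What is called first, only, known or untested is meant among the compounds shown, and "the series" means these compounds.

Measured compounds:
- Compound 1, `O=c1cc(-c2ccncc2)oc2ccc(OCCCCCCN3CCC(O)CC3)cc12`: 308 nM
- Compound 2, `O=c1cc(C2CCCCC2)oc2ccc(OCCCCCCN3CCC(O)CC3)cc12`: 46 nM

Both compounds were tested in an assay on isolated protein (Cavia porcellus) with Sigma non-opioid intracellular receptor 1 (Homo sapiens) as the target, read by radioligand binding; a higher number here means a weaker inhibitor, a lower number a stronger inhibitor. Going by the values given here, compound 2 stands at the lower of the two numbers, and the only measured step, a 6.7-fold lower number from compound 1 to compound 2 (0.83 log units; beyond the scatter), is the change of cyclohexyl in place of pyridin-4-yl on an aromatic carbon.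

Compound 3, `O=c1cc(C2CCCCC2)oc2ccc(OCCCCCCN3CCCCC3)cc12`, differs from compound 2 at another place: hydrogen in place of hydroxy on a saturated ring carbon. Among the compounds with values here, no measured step touches this part of the molecule, so the step from compound 1 to compound 2 gives no direct guidance; it only shows that a single change elsewhere moved this assay by a modest amount. With nothing shown to bear on the change, the expectation is a small shift, if any, close to the scatter, with either direction possible. The estimated step is a 1.5-fold lower number from compound 2 to compound 3 (0.19 log units; within the scatter). Compound 3 is therefore estimated at 30 nM, with a likely range from 8 nM to 110 nM.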

Compound 3, half-maximal inhibitory concentration: 32 nM
Beside the measured number, compound 3's estimate is 1.1-fold (0.03 log units) below it; the range from low to high includes it.
By their numbers in this assay, from the lowest: compounds 3 and 2 (each within the scatter of the next); then compound 1.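

In this assay, hydrogen in place of hydroxy on the saturated ring carbon gives a 1.4-fold lower number from compound 2 to compound 3 (0.16 log units; within the scatter), so compound 2 and compound 3 cannot be told apart by this measurement. Going by these compounds alone, this is the first look at this position, and it shows that, with cyclohexyl on the shared core, the hydroxy, with its hydrogen-bond donor and acceptor, can leave the piperidine ring with no shift beyond the usual scatter. Nothing given here offers an explanation for this result.

The compounds shown leave open whether an amine, a carboxylic acid or a methoxy group on that same ring carbon would also stay within the scatter of compound 3. Within the data shown here, also open is whether the same change would read alike on compound 1, which carries pyridin-4-yl: the one comparison here carries cyclohexyl.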